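Difluorophenyl for Phenyl: Expected Effect on Liver Clearance

The source may hold more compounds than are shown below. What is called first, only, known or untested is meant among the compounds shown, and "the series" means these compounds.

Three compounds built on one shared core have been run through an in vitro ADME assay on microsomes from liver (Homo sapiens) for metabolic stability, read by LC-MS, tested at 0.05 uM; on this read-out lower numbers stand for slow clearance and higher numbers for fast clearance. Compound 1 `COc1cnc(-c2ccccn2)nc1NCc1ccccc1C` gives 55 mL/min/kg. Compound 2 `COc1cnc(-c2ccccn2)nc1NCc1ccccc1` gives 67 mL/min/kg. Compound 3 `COc1cnc(-c2ccccn2)nc1NC(C)c1ccccc1` gives 65 mL/min/kg. Compound 2 therefore sits within the usual scatter of both other compounds: a 1.2-fold higher number from compound 1 to compound 2 (0.09 log units; within the scatter), and a 1.0-fold lower number from compound 2 to compound 3 (0.01 log units; within the scatter). Compound 4 `COc1cnc(-c2ccccn2)nc1NCc1ccc(F)cc1F` has not yet been measured; it differs from compound 2 by 2,4-difluorophenyl in place of phenyl on a saturated chain carbon bound to a nitrogen on an aromatic ring. For the measured compounds named here, the only earlier change on that same ring, a 1.2-fold higher number from compound 1 to compound 2 (0.09 log units; within the scatter), stayed within the scatter, and no measured step involves fluorine at all. In this assay a step of a 1.2-fold lower number from compound 2 to compound 4 (0.09 log units; within the scatter) is therefore expected, nothing beyond the scatter. Compound 4 is estimated at 55 mL/min/kg, within a range of 30 mL/min/kg to 95 mL/min/kg.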

Compound 4, clearance: 79 mL/min/kg
The estimate for compound 4 lay 1.4-fold (0.16 log units) below the measured number; the measured number falls inside the stated range.
By their numbers in this assay, from the lowest: compounds 1, 3, 2 and 4 (each within the scatter of the next).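

In this assay, 2,4-difluorophenyl in place of phenyl gives a 1.2-fold higher number from compound 2 to compound 4 (0.07 log units; within the scatter) and, in place of 2-methylphenyl, a 1.4-fold higher number from compound 1 to compound 4 (0.16 log units; within the scatter) on the same saturated chain carbon bound to a nitrogen on an aromatic ring. For the compounds shown here, this is the first fluorine seen at this position, and neither step leaves the scatter. Adding two fluorine atoms to the ring therefore gives no clearance difference that can be told from repeat-measurement noise. From the compounds shown here alone, whether an amine or a carboxylic acid on this ring would give a step beyond the scatter stays open. No measurement at hand offers a reason for these numbers.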